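Changing the Pendant Aryl Ring on a Shared Kinase Core

The source may hold more compounds than are shown below. What is called first, only, known or untested is meant among the compounds shown, and "the series" means these compounds.

Measured compounds:
Compound 1 `CCCS(=O)(=O)Nc1ccc(F)c(C(=O)c2n[nH]c3ncc(-c4ccc(F)cc4)cc23)c1F` gives 2.1% in an assay for binding affinity to dual specificity mitogen-activated protein kinase kinase 4 (Homo sapiens), read by KINOMEscan, tested at 100 nM; a lower number here means a stronger effect, a higher number a weaker effect of the compound at the concentration tested.
Compound 2 `CCCS(=O)(=O)Nc1ccc(F)c(C(=O)c2n[nH]c3ncc(-c4ccc(OC)cc4Cl)cc23)c1F` gives 5.3% in this assay.

Among the compounds with values here, compound 2 stands with the higher of the two numbers, but its only neighbour, compound 1, lies close, and the step of a number 3.2 percentage points higher from compound 1 to compound 2 (within the scatter) is within the scatter, so the two compounds cannot be told apart on these data. Both bind strongly at the concentration tested.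

Compound 3 `CCCS(=O)(=O)Nc1ccc(F)c(C(=O)c2n[nH]c3ncc(-c4ccc(S(=O)(=O)NC)cc4)cc23)c1F` differs from compound 2 at the same place: 4-(methylsulfamoyl)phenyl in place of 2-chloro-4-methoxyphenyl on an aromatic carbon. Within the data shown here, the one measured step, a number 3.2 percentage points higher from compound 1 to compound 2 (within the scatter), changed this same ring and left the read-out essentially unchanged, so a small step is expected in this assay, perhaps a modest rise, the step being estimated as a number 2.7 percentage points higher from compound 2 to compound 3 (within the scatter). Compound 3 is therefore expected to give about 8% in this assay, within a range from 1% to 30%.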

Compound 3, a percentage reported as activity, at one concentration (the size of the read-out at that concentration, not a potency): 1.2%
Beside the measured number, compound 3's estimate is 6.8 percentage points above it, and the stated range covers the measured number.
By their numbers in this assay, from the lowest: compounds 3, 1 and 2 (each within the scatter of the next).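

Swapping 2-chloro-4-methoxyphenyl for 4-(methylsulfamoyl)phenyl gives a number 4.1 percentage points lower from compound 2 to compound 3 (within the scatter) in this assay, and methylsulfamoyl in place of fluoro gives a number 0.9 percentage points lower from compound 1 to compound 3 (within the scatter) on the same ring. This position therefore accepts a larger group, one that brings a hydrogen-bond donor and a sulfur-containing substituent that the two earlier rings lack, with no difference that these data can resolve, so all three compounds remain indistinguishable at the single concentration tested. No measurement on hand explains why the read-out shows so little response to these changes.

From the compounds shown here alone, whether a carboxylic acid or an amine on this pendant ring would be accepted as well remains open. Also open, going by these compounds, is whether a longer chain on the sulfamoyl nitrogen would leave the read-out unchanged, and whether full potency measurements would separate these three compounds.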